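A few compounds are considered here, and "the series" means these few. Any claim that something is new, unique, unknown or untested is made for them only; others in the source may bear on it.

Measured compounds:
- compound 1 `COc1cccc(NC(=O)/C=C/c2coc3cc(OC)ccc3c2=O)c1` — 19200 nM
- compound 2 `Cc1ccc(CNC(=O)/C=C/c2coc3cc(O)ccc3c2=O)cc1` — a limit of the assay, > 100000 nM

Going by the values given here, in a functional assay on HeLa cells (Homo sapiens) for inhibition, read by MTT assay, with a stated time of 48 h (on this read-out higher numbers stand for weaker inhibition and lower numbers for stronger inhibition), compound 1 gives 19200 nM, the only finite number so far. Among the compounds with values here, compound 2 is reported only as a limit, (the limit of > 100000 nM in this assay, at which 1 of the 2 values shown sits), so no step between the two measured compounds can be sized. Compound 3 `COc1ccc2c(=O)c(/C=C/C(=O)Nc3ccc(C)cc3)coc2c1` is the next member; relative to compound 1 the change is 4-methylphenyl in place of 3-methoxyphenyl on an amide-type nitrogen. Within the data shown here, no measured pair carries this particular change, so there is nothing to calibrate against. With one finite value and one limit, the working expectation is a step from compound 1 that stays within the usual scatter of this assay, with no direction preferred. On that basis compound 3 is expected to give 25000 nM in this assay, with a range of 8000 nM to 80000 nM. The expected step is estimated as a 1.3-fold higher number from compound 1 to compound 3 (0.11 log units; within the scatter).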

Compound 3, half-maximal inhibitory concentration: 24100 nM
Beside the measured number, compound 3's estimate is 1.0-fold (0.02 log units) above it, within the range that was stated.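

In this assay, going by these compounds alone, 4-methylphenyl in place of 3-methoxyphenyl on an amide-type nitrogen gives a 1.3-fold higher number from compound 1 to compound 3 (0.10 log units; within the scatter), the one step that can be read. The leaving group carries a hydrogen-bond acceptor and the entering group carries none, yet compound 1 and compound 3 read alike, so at this position that acceptor is not needed to keep the number in this range. Nothing shown gives a reason for this result.

Compound 2 is a limit of the assay, and steps to it cannot be read: the limit of > 100000 nM in this assay, at which 1 of the 3 values shown sits. From the compounds shown here alone, it remains open whether an amine or a carboxylic acid on the phenyl ring, or a longer chain on the amide-type nitrogen, would move the number beyond the scatter.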